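From 2-hydroxyethyl to 3-hydroxypropyl at the assay limit

This account rests on a few compounds, and the source may have more. Where it says the series, first, only, none or still open, it means among the compounds named here.

- compound 1 (`N#Cc1ncc2nc1OCC/C=C\COc1ccc(OCCOC3CCCCO3)cc1NC(=O)N2`): > 10000 nM (a limit)
- compound 2 (`N#Cc1ncc2nc1OCC/C=C\COc1ccc(CCO)cc1NC(=O)N2`): > 10000 nM (a limit)

In a functional assay on NCI-H1299 cells (Homo sapiens), read by flow cytometry (on this read-out lower numbers stand for an effect already at smaller amounts and higher numbers for an effect only at larger amounts of compound), compound 2 gives > 10000 nM as its result, which is a limit of the assay and not a number. Neither measured compound has a number yet (the limit of > 10000 nM in this assay, at which 2 of the 2 values shown sit). Compound 3 (`N#Cc1ncc2nc1OCC/C=C\COc1ccc(CCCO)cc1NC(=O)N2`) differs from compound 2 by one change (hydroxymethyl in place of hydroxy on a saturated chain carbon, two bonds along the chain from an aromatic carbon), which turns 2-hydroxyethyl into 3-hydroxypropyl. Within the data shown here, the only measured step (a step that the two limits leave unreadable from compound 1 to compound 2) gives no size to carry over, so no shift beyond the usual scatter is expected in this assay and a further limit is the likeliest result. The expected step is small (a step that the limit leaves unreadable from compound 2 to compound 3). Compound 3 is estimated at 12000 nM with an expected range from 3000 nM to 40000 nM if a number is obtained at all.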

Compound 3, half-maximal effective concentration: > 10000 nM
Compound 3: no number, only a limit; the forecaster's own chance of this, stated with the estimate: 80%; the middle value lies beyond the limit too.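

No step among compound 1, compound 2 and compound 3 can be read, as each result is a limit of the assay and not a number: the limit of > 10000 nM in this assay, at which 3 of the 3 values shown sit.

The compounds shown leave open how large these steps really are, and whether any group at this place gives a number in this assay at all.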